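Aminopiperidine series: heteroaryl swap on the ring nitrogen

The source may report more compounds than this note shows. Statements on the series, on what has been measured and on what is new or still open speak of the compounds shown alone.

Measured so far, in a functional assay on CHO-K1 cells for agonist activity at Glucose-dependent insulinotropic receptor (Homo sapiens), read by HTRF and cAMP accumulation, with a stated time of 30 min; a higher number here means that more compound is needed for the effect, a lower number that less compound is needed:
- compound 1 `CC(C)(C)OC(=O)N1CCC(CCCNc2ccc3c(c2)OCCS3(=O)=O)CC1`: 511 nM
- compound 2 `COc1cnc(N2CCC(CCCNc3ccc4c(c3)OCC4=O)CC2)nc1`: 115 nM

Compound 2 carries the lowest number of the two. Compound 1 sits higher, and the gap between the two values lies beyond the usual scatter; the two structures differ in more than one place, so the two values are noted side by side without being read as a single step.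

Compound 3 `CC(C)c1nsc(N2CCC(CCCNc3ccc4c(c3)OCC4=O)CC2)n1` is not yet measured. It differs from compound 2 in one place: 3-isopropyl-1,2,4-thiadiazol-5-yl in place of 5-methoxypyrimidin-2-yl on an amine nitrogen in a ring. The group that leaves and the group that enters have the same count of heavy atoms and of acceptors; the ring changes from six-membered to five-membered with an added hetero atom, and an isopropyl replaces a methoxy.

Among the measured compounds shown here, no measured pair in this set isolates a change of this kind, so there is nothing to scale the step against. The working expectation is that the step from compound 2 to compound 3 stays within the scatter, a 1.3-fold higher number from compound 2 to compound 3 (0.12 log units; within the scatter), with the range opened on both sides to allow for a moderate move in either direction. Compound 3 is therefore estimated at 150 nM, between 50 nM and 450 nM.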

Compound 3, half-maximal effective concentration: 121 nM
Compound 3: middle estimate off by 1.2-fold (0.09 log units), on the high side; the measured number falls inside the stated range.
By their numbers in this assay, from the lowest: compounds 2 and 3 (each within the scatter of the next); then compound 1.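

In this assay, among the compounds shown here, the swap on the amine nitrogen in the ring gives a 1.1-fold higher number from compound 2 to compound 3 (0.02 log units; within the scatter) and is the first single-place step in this set, so this position now has a direct reading: 3-isopropyl-1,2,4-thiadiazol-5-yl and 5-methoxypyrimidin-2-yl cannot be told apart by this number. The change of a six-membered aromatic ring with 2 hetero atoms to a five-membered aromatic ring with 3 hetero atoms, with oxygen leaving and sulfur entering at equal counts of heavy atoms and acceptors, leaves the value within the scatter, a finding that holds for this one pair only. No measured property bears on why the two groups read alike.

The compounds shown leave open how far this holds on the same nitrogen for groups of another kind, such as an unsubstituted phenyl ring, an acetyl group or a cyclopropyl or trifluoromethyl in place of the isopropyl on the thiadiazole. Compound 1 differs from compound 2 in more than one place, so the share of its higher number that belongs to the group on the ring nitrogen also stays unresolved.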